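The compounds below may be only part of what the source reports. "The series", "measured", "known", "first", "only" and "open" are said of these compounds alone.

Working notes on the series

Compound 1 `COc1ccc(/C=N/N(C)C(=O)c2ccccc2OC)cc1OC`, compound 2 `COc1cccc(C(=O)N(C)/N=C/c2ccc(OC)c(OC)c2)c1` and compound 3 `COc1ccc(/C=N/N(C)C(=O)c2ccccc2)cc1OC` share one core and differ only in the ring on the carbonyl. In a functional assay on the whole organism (strain A/J) for inhibition, with Mus musculus as the target, with stated times of 1 h and 18 h, at a dose of 100 umol/kg by the oral route (a lower number here means less inhibition, a higher number more inhibition at the dose given (going by the name of the read-out)), compound 1 gives 61%, compound 2 gives 70% and compound 3 gives 58%. Compound 3 thus stands lowest of the three numbers, but the margin is uneven: the step of a number 3 percentage points lower from compound 1 to compound 3 (within the scatter) lies within the scatter, while the step of a number 12 percentage points lower from compound 2 to compound 3 (beyond the scatter) goes beyond it, and the step of a number 9 percentage points higher from compound 1 to compound 2 (within the scatter) is itself within the scatter.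

Compound 4 `COc1ccc(/C=N/N(C)C(=O)c2ccc(O)cc2)cc1OC` has not been measured in this assay. It differs from compound 3 by hydroxy in place of hydrogen on an aromatic carbon. The measured steps that bear on it are the two in which a methoxy on the same ring was replaced by hydrogen, both ending at compound 3: one within the scatter, one a modest loss beyond it. Among the compounds with values here, neither involves a hydroxy, so the bearing is indirect; they show only that a group on that ring has not lowered inhibition. The step from compound 3 to compound 4 is therefore expected to be small, a number 5 percentage points higher from compound 3 to compound 4 (within the scatter), with no confident direction beyond the scatter. Compound 4 is estimated to give 63% in this assay, within a range of 48% to 78%.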

Compound 4, a percentage reported as inhibition, in the whole organism at one dose (the size of the read-out at that dose, not a potency): 36%
Compound 4: the middle estimate sits 27 percentage points above what was measured; measured number below the stated range.
By their numbers in this assay, from the lowest: compound 4; then compounds 3, 1 and 2 (each within the scatter of the next, the first and the last beyond it).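

Within the data shown here, the phenyl to 4-hydroxyphenyl change, which puts hydroxy para to a large group, is the first change on this ring in this assay to give a step down from compound 3 beyond the scatter: a number 22 percentage points lower from compound 3 to compound 4 (beyond the scatter). The comparisons with the two methoxy compounds point the same way, a number 25 percentage points lower from compound 1 to compound 4 (beyond the scatter) and a number 34 percentage points lower from compound 2 to compound 4 (beyond the scatter), so compound 4 stands apart from the other three, with the lowest number of the four. The ring on the carbonyl is therefore not indifferent to what it carries: the methoxy of compound 1 leaves the number within the scatter of compound 3, the methoxy of compound 2 gives a number beyond the scatter above compound 3, and hydroxy gives one beyond the scatter below it.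

Nothing shown here explains the drop seen with hydroxy. The compounds shown also leave open whether the loss goes with hydroxy itself or with any group at this place, a question that a 4-methoxyphenyl, a 4-aminophenyl or a 4-carboxyphenyl ring on the same core would address.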